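A few compounds are considered here, and "the series" means these few. Any claim that something is new, unique, unknown or untested is made for them only; others in the source may bear on it.

Of the compounds shown here, three that share one core have so far been measured in a functional assay on HCT-116 cells (Homo sapiens) for cytotoxicity, read by sulforhodamine B assay, with a stated time of 48 h (a higher number here means a weaker inhibitor, a lower number a stronger inhibitor), and give the following picture. Compound 1 (`CCCCNC(=O)N1Cc2c(NC(=O)c3ccc(OC)cc3)nn(C(=O)c3ccccc3)c2C1`) gives 25300 nM in this test, compound 2 (`O=C(Nc1nn(C(=O)c2ccccc2)c2c1CN(C(=O)c1ccccc1)C2)c1ccccc1`) gives 1400 nM and compound 3 (`O=C(Nc1nn(C(=O)c2ccccc2)c2c1CN(C(=O)c1ccccc1)C2)c1ccc(F)cc1`) gives 2780 nM under the same conditions. Compound 3 thus lies within the scatter of compound 2 and well under compound 1, a gap that is beyond the scatter. Compound 4 (`COc1ccc(C(=O)Nc2nn(C(=O)c3ccccc3)c3c2CN(C(=O)c2ccccc2)C3)cc1`) differs from compound 3 at a single place, with methoxy in place of fluoro on an aromatic carbon para to a large group. Within the data shown here, the one measured step at this place is a 2.0-fold higher number from compound 2 to compound 3 (0.30 log units; within the scatter) and it came with fluoro in place of hydrogen on an aromatic carbon. Compound 4 shares the ((4-methoxyphenyl)carbonyl)amino group with compound 1, but the two differ elsewhere, so the number for compound 1 cannot isolate that group. With that single small step as the guide, no change beyond the scatter is expected in this assay for this swap. The expected step is a 1.1-fold lower number from compound 3 to compound 4 (0.05 log units; within the scatter) and would stay within the scatter. For compound 4 the estimated value is 2500 nM in this test. The expected range for compound 4 runs from 1000 nM to 7000 nM in the same test.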

Compound 4, half-maximal inhibitory concentration: 31300 nM
Compound 4: the middle estimate sits 13-fold (1.10 log units) below what was measured, outside the stated range (above it).
By their numbers in this assay, from the lowest: compounds 2 and 3 (each within the scatter of the next); then compounds 1 and 4 (each within the scatter of the next).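

At this place on the aromatic ring, this assay proves sensitive to the group present: methoxy in place of fluoro gives an 11-fold higher number from compound 3 to compound 4 (1.05 log units; beyond the scatter) and methoxy in place of hydrogen gives a 22-fold higher number from compound 2 to compound 4 (1.35 log units; beyond the scatter) even though fluoro in place of hydrogen had given only a 2.0-fold higher number from compound 2 to compound 3 (0.30 log units; within the scatter) within the scatter. The small earlier step therefore gave no sign of how far compound 4 would stand from both compound 2 and compound 3, and with the 4-methoxyphenyl group held constant, phenyl in place of butylamino on the carbonyl carbon gives a 1.2-fold higher number from compound 1 to compound 4 (0.09 log units; within the scatter) and no change beyond the scatter. No measured evidence is available that bears on this result.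

The compounds shown leave open whether the large step belongs to methoxy alone or would also come with another group at this place, such as an amine, a hydroxyl or a longer ethoxy chain. They also leave open whether a butylamino compound carrying hydrogen or fluoro at this place would follow compound 2 and compound 3 or would keep the level shared by compound 1 and compound 4.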